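The source may hold more compounds than are shown below. What is called first, only, known or untested is meant among the compounds shown, and "the series" means these compounds.

Compound 1 `CN1C(=O)C2(C(C#N)=C(N)Oc3cc4oc(-c5ccccc5)cc(=O)c4c(O)c32)c2cc(Cl)ccc21` gives 4720 nM in a functional assay on A549 cells (Homo sapiens) for antiproliferative activity, read by MTT assay, with a stated time of 48 h; a lower number here means a stronger inhibitor, a higher number a weaker inhibitor. Compound 2 `COc1ccc2c(c1)C1(C(=O)N2Cc2ccccc2)C(C#N)=C(N)Oc2cc3oc(-c4ccccc4)cc(=O)c3c(O)c21` gives > 50000 nM.

For compound 2 that figure is a limit of this assay and not a number: it is the limit of > 50000 nM in this assay, at which 1 of the 2 values shown sits. Where compound 2 stands is therefore known only as a bound. Compound 3 `N#CC1=C(N)Oc2cc3oc(-c4ccccc4)cc(=O)c3c(O)c2C12C(=O)N(Cc1ccccc1)c1ccc(Cl)cc12` differs from it by chloro in place of methoxy on an aromatic carbon. Compound 1, also carrying the chloro, gives 4720 nM. On that basis compound 3 is expected to inhibit more strongly than the bound, with a step of an at least 2.5-fold lower number from compound 2 to compound 3 (0.39 log units; beyond the scatter) taken as the expectation. Compound 3 is estimated at 20000 nM, between 5000 nM and 60000 nM.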

Compound 3, half-maximal inhibitory concentration: > 50000 nM
Compound 3: no number, only a limit; the forecaster's own chance of this, stated with the estimate: 40%; middle value at least 2.5-fold (0.39 log units) from the limit.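

In this assay compound 3 gives > 50000 nM, a limit and not a number, and compound 2 stands at the same limit, so the step between them cannot be read: the limit of > 50000 nM in this assay, at which 2 of the 3 values shown sit. With the chloro kept, phenyl in place of hydrogen on the saturated chain carbon bound to the amide-type nitrogen in a ring gives an at least 10-fold higher number from compound 1 to compound 3 (1.02 log units; beyond the scatter). Chloro in place of methoxy thus brings no readable value while that phenyl is present.

On these data alone, whether methoxy and chloro differ once the phenyl is gone stays open. So does how an ethyl chain, or an amine on that chain, would read.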